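The source may hold more compounds than are shown below. What is called first, only, known or untested is meant among the compounds shown, and "the series" means these compounds.

Measured in an in vitro ADME assay on microsomes from liver (Homo sapiens) for metabolic stability; on this read-out higher numbers stand for fast clearance and lower numbers for slow clearance:
- Compound 1 `Cc1ccc(Cn2c(=O)[nH]c3c(N)nc(C(F)(F)F)cc32)nn1` gives < 8 mL.min-1.g-1 as a limit
- Compound 2 `Cc1cccc(Cn2c(=O)[nH]c3c(N)nc(C(F)(F)F)cc32)n1` gives < 8 mL.min-1.g-1 as a limit
- Compound 3 `CN1CCN(c2ccc(Cn3c(=O)[nH]c4c(N)nc(C(F)(F)F)cc43)cn2)CC1` gives 30 mL.min-1.g-1 as a number

Compound 3 alone has a real number, as the other two values shown are limits. Compound 4 `COc1ccc(Cn2c(=O)[nH]c3c(N)nc(C(F)(F)F)cc32)cn1` has methoxy in place of 4-methylpiperazin-1-yl on an aromatic carbon. Among the compounds with values here, the one measured step is a step that the two limits leave unreadable from compound 1 to compound 2 and so gives no size to carry over. Within the data shown here, compound 1 and compound 2 also lack the 4-methylpiperazin-1-yl, and both stand at the limit of < 8 mL.min-1.g-1 in this assay, at which 2 of the 3 values shown sit, as the only guide. In this assay a step towards slower clearance, beyond the scatter, is therefore expected (a 2.7-fold lower number from compound 3 to compound 4 (0.44 log units; beyond the scatter)). For compound 4 the estimate is 11 mL.min-1.g-1 with an expected range from 6 mL.min-1.g-1 to 20 mL.min-1.g-1 and the assay may well report only a limit.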

Compound 4, intrinsic clearance in microsomes: < 8 mL.min-1.g-1
Compound 4 ended at the assay's limit (the forecaster's own chance of this, stated with the estimate: 40%); middle value at least 1.3-fold (0.13 log units) from the limit.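

In this assay, methoxy in place of 4-methylpiperazin-1-yl on this aromatic carbon brings an at least 3.7-fold lower number from compound 3 to compound 4 (0.57 log units; beyond the scatter), the first step with a readable size among these compounds. The result for compound 4 is a limit, so this size is only a minimum. The steps among compound 1, compound 2 and compound 4 cannot be read, and the values offer little to separate such compounds: the limit of < 8 mL.min-1.g-1 in this assay, at which 3 of the 4 values shown sit.

On these data alone, it remains open where a morpholine ring or a dimethylamine at this carbon would fall in this assay. As far as these compounds go, it also remains open whether the outer methyl of the 4-methylpiperazin-1-yl group plays any part in the difference.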